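Cyclopentyl in place of cyclohexyl: compound 3 to compound 4

The compounds below may be only part of what the source reports. "The series", "measured", "known", "first", "only" and "open" are said of these compounds alone.

Compound 1 `CC(C)=CCOc1cccc(O)c1C(=O)/C=C/c1ccc(O)cc1`: > 30000 nM
Compound 2 `O=C(/C=C/c1ccc(O)cc1)c1c(O)cccc1OCCC1CCCCC1`: > 30000 nM
Compound 3 `O=C(/C=C/c1ccc(O)cc1)c1c(O)cccc1OCC1CCCCC1`: > 30000 nM

All three entries come from a functional assay on MDA-MB-231 cells (Homo sapiens) for antiproliferative activity, read by sulforhodamine B assay (on this read-out higher numbers stand for weaker inhibition of growth and lower numbers for stronger inhibition of growth), and each is a limit, not a number. Within the data shown here, the series so far shows (the limit of > 30000 nM in this assay, at which 3 of the 3 values shown sit).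

Compound 4 `O=C(/C=C/c1ccc(O)cc1)c1c(O)cccc1OCC1CCCC1` differs from compound 3 by cyclopentyl in place of cyclohexyl on a saturated chain carbon bound to an oxygen on an aromatic ring.

The nearest changes on that carbon are a step that the two limits leave unreadable from compound 2 to compound 3, a step that the two limits leave unreadable from compound 1 to compound 3 and a step that the two limits leave unreadable from compound 1 to compound 2. None of these gives a size to carry over. No step beyond the scatter, in either direction, is therefore expected in this assay.

The expected change is a number no higher from compound 3 to compound 4 (the limit leaves the size open).

Compound 4 is estimated at 30000 nM, with an expected range of 12000 nM to 60000 nM.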

Compound 4, concentration for 50% growth inhibition: 3410 nM
Beside the measured number, compound 4's estimate is 8.8-fold (0.94 log units) above it, and the stated range ends above it.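

In this assay, the group on the saturated chain carbon bound to an oxygen on an aromatic ring now gives a readable change: cyclopentyl in place of cyclohexyl gives an at least 8.7-fold lower number from compound 3 to compound 4 (0.94 log units; beyond the scatter). Against the other two groups, the same position gives an at least 8.7-fold lower number from compound 2 to compound 4 (0.94 log units; beyond the scatter) and an at least 8.7-fold lower number from compound 1 to compound 4 (0.94 log units; beyond the scatter). All three sizes are open-ended, each resting on a limit rather than a number: the limit of > 30000 nM in this assay, at which 3 of the 4 values shown sit.

Going by these compounds, whether cyclobutyl, an open pentyl chain or a cyclopentyl ring carrying an amine would keep this growth inhibition remains open. On these data alone, how far the cyclohexyl, cyclohexylmethyl and 2-methylprop-1-en-1-yl compounds lie beyond their limit also remains open.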